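The source may hold more compounds than are shown below. What is called first, only, known or untested is meant among the compounds shown, and "the series" means these compounds.

Working notes on the series. Among the measured compounds shown here, compound 1 `COc1ccc(-c2nc(N=C(N)N)sc2-c2ccc(OC)cc2)cc1` gives 2 uM in a functional assay (aorta) with Rattus norvegicus as the target (on this read-out lower numbers stand for an effect already at smaller amounts and higher numbers for an effect only at larger amounts of compound), the lowest of the three numbers so far. Compound 2 `COc1ccc(-c2nc(CNC(=O)CSC)sc2-c2ccc(OC)cc2)cc1` gives 6 uM in this assay, and compound 3 `COc1ccc(-c2nc(CNC(=O)C3=NNC(=O)CC3)sc2-c2ccc(OC)cc2)cc1` gives 7.3 uM in this assay. Compound 4 `COc1ccc(-c2nc(CNC(=O)NC(C)C)sc2-c2ccc(OC)cc2)cc1` remains to be measured in this assay.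

Compound 4 differs from compound 1 by a group of 8 heavy atoms (5 carbon, 2 nitrogen, 1 oxygen; no ring) in place of a group of 4 heavy atoms (1 carbon, 3 nitrogen; no ring), on an aromatic carbon. For the measured compounds named here, the step that bears most directly on this is the one from compound 1 to compound 2, where the same group leaves the same aromatic carbon and a chain of comparable size enters: a 3.0-fold higher number from compound 1 to compound 2 (0.48 log units; beyond the scatter). The step from compound 2 to compound 3, which alters only the group on the carbonyl carbon, stays small: a 1.2-fold higher number from compound 2 to compound 3 (0.09 log units; within the scatter). The change in compound 4 keeps the methylene-amide pattern of compounds 2 and 3 and varies only the part on the carbonyl carbon, so a step of the size seen from compound 1 to compound 2 is expected, in the direction of a higher number: a 3.0-fold higher number from compound 1 to compound 4 (0.48 log units; beyond the scatter). Compound 4 is therefore expected to give about 6 uM in this assay, with a range of 3 uM to 13 uM.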

Compound 4, concentration for half-maximal effect: 5.7 uM
Beside the measured number, compound 4's estimate is 1.1-fold (0.02 log units) above it; the measured number falls inside the stated range.
By their numbers in this assay, from the lowest: compound 1; then compounds 4, 2 and 3 (each within the scatter of the next).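

With the ((isopropylcarbamoyl)amino)methyl group on this aromatic carbon, the read-out in this assay still gives a 2.9-fold higher number from compound 1 to compound 4 (0.45 log units; beyond the scatter), although the entering group has the same count of hydrogen-bond donors and acceptors as the group that leaves, so matching those counts does not close the gap to compound 1. On the carbonyl carbon, isopropylamino now gives a 1.1-fold lower number from compound 2 to compound 4 (0.02 log units; within the scatter) and a 1.3-fold lower number from compound 3 to compound 4 (0.11 log units; within the scatter), so three quite different groups at that place, one of them a ring, stay within the scatter of each other. No supporting measurement is at hand to explain either finding.

The compounds shown do not separate the contribution of the methylene-amide link from that of the group on the carbonyl carbon. Going by these compounds, how a carboxylic acid, a primary amine or a longer alkyl chain at that carbonyl carbon would read remains open.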